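This account rests on a few compounds, and the source may have more. Where it says the series, first, only, none or still open, it means among the compounds named here.

Compound 1 `COC1Cc2c(cnn2-c2ccccc2)C2(CCN(CCCc3ccccc3)CC2)O1`: 3.2 nM
Compound 2 `COC1Cc2c(cnn2-c2ccccc2)C2(CCN(C(C)C)CC2)O1`: 210 nM

In an assay for displacement of a labelled ligand from Sigma non-opioid intracellular receptor 1 (Cavia porcellus), read by scintillation counting, with a stated time of 180 min (a higher number here means a weaker inhibitor, a lower number a stronger inhibitor), compound 2 gives 210 nM, the highest of the two numbers; its nearest neighbour is compound 1, which gives 3.2 nM. Among the measured compounds shown here, the only measured step, a 66-fold higher number from compound 1 to compound 2 (1.82 log units; beyond the scatter), shows that shortening the chain on the ring amine weakens binding strongly. Compound 3 `CCCCCN1CCC2(CC1)OC(OC)Cc1c2cnn1-c1ccccc1` differs from compound 2 by pentyl in place of isopropyl on an amine nitrogen in a ring, bringing back a longer chain, as in compound 1 but without its ring. Compound 3 is therefore expected to change by a 21-fold lower number from compound 2 to compound 3 (1.32 log units; beyond the scatter), toward a lower number. The estimate for compound 3 is 10 nM, within 3 nM to 40 nM.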

Compound 3, inhibition constant: 0.82 nM
Compound 3: middle estimate off by 12-fold (1.09 log units), on the high side; the whole stated range lies above it.
By their numbers in this assay, from the lowest: compound 3; then compound 1; then compound 2.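

In this assay, the ring amine nitrogen does not need a phenyl group at the end of its chain for strong binding: ethyl in place of that phenyl gives a 3.9-fold lower number from compound 1 to compound 3 (0.59 log units; beyond the scatter) in the same direction as a gain in binding. A plain pentyl chain also far outperforms isopropyl, with a 260-fold lower number from compound 2 to compound 3 (2.41 log units; beyond the scatter) at this same position. No measurement here explains either step.

Pentyl differs from isopropyl in both length and branching, so the two effects remain unseparated. Going by these compounds, how butyl or hexyl would behave also stays open.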